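A few compounds are considered here, and "the series" means these few. Any claim that something is new, unique, unknown or untested is made for them only; others in the source may bear on it.

Compound 1 `COc1ccc(Cl)cc1C(=O)NCCC1CCN(S(=O)(=O)NC(=O)NC[C@@H]2C[C@@H]3C=C[C@@H]2C3)CC1`: 27%
Compound 2 `COc1ncc(Cl)cc1C(=O)NCCC1CCN(S(=O)(=O)NC(=O)NC[C@@H]2C[C@@H]3C=C[C@@H]2C3)CC1`: 20%
Compound 3 `O=C(NC[C@@H]1C[C@@H]2C=C[C@@H]1C2)NS(=O)(=O)N1CCC(CCNC(=O)c2nc3ccccc3s2)CC1`: 14%

In a functional assay on the whole organism (blood) with Rattus norvegicus as the target, with stated times of 24 h and 1 h, at a dose of 1 mg/kg by the intraperitoneal route (on this read-out lower numbers stand for a weaker effect and higher numbers for a stronger effect at the one dose given), compound 3 holds the lowest of the three numbers. Within the data shown here, its nearest neighbour is compound 2, a gap that stays within the scatter, while the gap to compound 1 is beyond it; the one step beyond the scatter here is a number 13 percentage points lower from compound 1 to compound 3 (beyond the scatter). Compound 4 `Cn1cc(C(=O)NCCC2CCN(S(=O)(=O)NC(=O)NC[C@@H]3C[C@@H]4C=C[C@@H]3C4)CC2)c(=O)n(C)c1=O` changes the group on that same carbonyl carbon: a group of 10 heavy atoms (6 carbon, 2 nitrogen, 2 oxygen; one six-membered aromatic ring with 2 hetero atoms) in place of a group of 9 heavy atoms (7 carbon, 1 nitrogen, 1 sulfur; one five-membered aromatic ring with 2 hetero atoms, one six-membered aromatic ring of carbon only), on a carbonyl carbon. Among the measured compounds shown here, the steps that bear on this position are a number 7 percentage points lower from compound 1 to compound 2 (within the scatter) and a number 6 percentage points lower from compound 2 to compound 3 (within the scatter), both within the scatter, and the modest one already named. For the measured compounds named here, none of them involves the group that enters compound 4, and no measured compound carries it. The step of a number 1 percentage points higher from compound 3 to compound 4 (within the scatter) is therefore expected to remain within the scatter. Compound 4 is estimated at 15%, with a range from 4% to 30%.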

Compound 4, a percentage reported as activity, at one dose (the size of the read-out at that dose, not a potency): 12%
Compound 4: the middle estimate sits 3 percentage points above what was measured, and the stated range covers the measured number.
By their numbers in this assay, from the lowest: compounds 4, 3, 2 and 1 (each within the scatter of the next, the first and the last beyond it).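

In this assay, the group that enters on the carbonyl carbon has a single six-membered aromatic ring with 2 hetero atoms, and a number 2 percentage points lower from compound 3 to compound 4 (within the scatter) shows no separation from 1,3-benzothiazol-2-yl. Likewise, a number 8 percentage points lower from compound 2 to compound 4 (within the scatter) shows no separation from 5-chloro-2-methoxypyridin-3-yl. Only a number 15 percentage points lower from compound 1 to compound 4 (beyond the scatter) goes beyond the scatter, matching a number 13 percentage points lower from compound 1 to compound 3 (beyond the scatter) in that respect.

On these data alone, whether a cyclohexyl group or an open alkyl chain at this position would behave differently remains open. Nothing given here explains these steps.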